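This account rests on a few compounds, and the source may have more. Where it says the series, first, only, none or still open, it means among the compounds named here.

Measured compounds:
compound 1, `CC[C@@H]1C(=O)N(C)c2cnc(-n3ccc4cc(F)ccc43)nc2N1C1CCCC1`: "not active" (no number reported)
compound 2, `CCC1C(=O)N(C)c2cnc(-n3ccc4cc(C(N)=O)ccc43)nc2N1c1ccn(C)n1`: 27400 nM
compound 3, `CC[C@@H]1C(=O)N(C)c2cnc(Nc3ccc(S(=O)(=O)NC4CCCC4)cc3)nc2N1C1CCCC1`: 609 nM

The account concerns three measured compounds and one that is yet to be tested in a functional assay on HeLa cells (Homo sapiens) for antiproliferative activity, read by CCK-8 assay, with a stated time of 72 h; a lower number here means a stronger inhibitor of growth, a higher number a weaker inhibitor of growth. Compound 1 was reported as "not active" (no number reported), with no number given. Among the two compounds with numbers, compound 2 stands at the high end: in this assay compound 2 gives 27400 nM, whereas compound 3 gives 609 nM, a much lower number and a gap that lies well beyond the usual scatter. Compound 2 is therefore the weaker of the two numbered compounds.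

The step now followed leads from compound 2 to compound 4, `CCC1C(=O)N(C)c2cnc(-n3ccc4cc(C(=O)NCC(C)C)ccc43)nc2N1c1ccn(C)n1`. The change is isobutyl in place of hydrogen on an amide-type nitrogen; in other words, the amino of the carbamoyl becomes an isobutylamino. Within the data shown here, no measured pair in this set shows this kind of change, so its effect cannot be read off from the data. The expectation rests on compound 2 alone and on the small size of the change, which adds a short chain without a ring or a new donor or acceptor.

Given that, compound 4 is expected to stay near compound 2, with a step of a 1.8-fold lower number from compound 2 to compound 4 (0.26 log units; within the scatter), leaning toward a somewhat lower number but not with confidence beyond the scatter. The estimate for compound 4 in this assay is 15000 nM, within a range from 4000 nM to 50000 nM.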

Compound 4, concentration for 50% growth inhibition: 4970 nM
The estimate for compound 4 lay 3.0-fold (0.48 log units) above the measured number; measured number inside the range.
By their numbers in this assay, from the lowest: compound 3; then compound 4; then compound 2.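

In this assay, among these compounds, the amide-type nitrogen of the carbamoyl group proves open to substitution: isobutyl in place of hydrogen gives a 5.5-fold lower number from compound 2 to compound 4 (0.74 log units; beyond the scatter) and is the only single-place step available in this set. The step is modest, yet it shows that this hydrogen can give way to a short chain without a ring, and that the number falls rather than rises, something compounds 1, 2 and 3 could not show on their own. Nothing in hand explains why the isobutyl group lowers the number.

On these data alone, a single chain cannot show whether the effect follows chain size or shape, so it remains open whether a methyl group, a longer chain such as n-hexyl or a cyclopentyl ring on the same nitrogen would lower the number further or lose the gain. As far as these compounds go, it also remains open whether an amine or a carboxylic acid at the end of the isobutyl chain would be accepted, and whether replacing the second amide hydrogen as well would change the number.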